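The source may report more compounds than this note shows. Statements on the series, on what has been measured and on what is new or still open speak of the compounds shown alone.

Compound 1 `COc1ccc(-c2cn3cc(C4=CCN(C(=O)c5ccccc5C(F)(F)F)CC4)ccc3n2)cc1OC`: in a functional assay on HeLa cells (Homo sapiens) for antiproliferative activity, read by MTT assay, with a stated time of 48 h (a higher number here means a weaker inhibitor, a lower number a stronger inhibitor), compound 1 gives 7950 nM.
Compound 2 `COc1ccc(-c2cn3cc(C4=CCN(C(=O)C5CC5)CC4)ccc3n2)cc1OC`: in this assay compound 2 gives 15800 nM.

Among the measured compounds shown here, compound 2 has the highest of these two numbers, and the only measured step, a 2.0-fold higher number from compound 1 to compound 2 (0.30 log units; within the scatter), stays within the scatter. Compound 3 `COc1ccc(-c2cn3cc(C4=CCN(C(=O)c5cccs5)CC4)ccc3n2)cc1OC` carries the change (thiophen-2-yl in place of cyclopropyl on a carbonyl carbon). Compound 3 resembles compound 1 in having a flat aromatic ring on the carbonyl carbon, and compound 1 gives 7950 nM, so the expectation is a number near that of compound 1, close to the reverse of the step from compound 1 to compound 2. The expected step is a 1.8-fold lower number from compound 2 to compound 3 (0.24 log units; within the scatter), within the scatter. Compound 3 is therefore estimated at 9000 nM, with a range from 3500 nM to 25000 nM.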

Compound 3, half-maximal inhibitory concentration: 16000 nM
Estimate against measurement, compound 3: 1.8-fold (0.25 log units) below, within the range that was stated.
By their numbers in this assay, from the lowest: compounds 1, 2 and 3 (each within the scatter of the next).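

In this assay, thiophen-2-yl in place of cyclopropyl on the carbonyl carbon gives a 1.0-fold higher number from compound 2 to compound 3 (0.01 log units; within the scatter), and thiophen-2-yl in place of 2-(trifluoromethyl)phenyl gives a 2.0-fold higher number from compound 1 to compound 3 (0.30 log units; within the scatter), so both steps stay within the scatter. An aromatic ring here therefore does not by itself set compound 3 apart from compound 2, whose cyclopropyl ring is non-aromatic. No measured evidence explains this result. On these data alone, what remains open is whether an aminomethyl group or a longer alkyl chain on this carbonyl carbon would shift the number beyond the scatter.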